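Lengthening the amine chain from ethyl to pentyl

The compounds below may be only part of what the source reports. "The series", "measured", "known", "first", "only" and "open" are said of these compounds alone.

In a physicochemical assay for solubility (on this read-out lower numbers stand for lower solubility and higher numbers for higher solubility), compound 1 `CCCNC1CC(=O)OC1C(O)C(=O)NC(CC(C)C)C1Cc2cccc(O)c2C(=O)O1` gives > 100000 ug/mL, which is a limit of the assay and not a number.
In this assay compound 2 `CCNC1CC(=O)OC1C(O)C(=O)NC(CC(C)C)C1Cc2cccc(O)c2C(=O)O1` gives > 100000 ug/mL, again a limit rather than a number.
In this assay compound 3 `CCCCNC1CC(=O)OC1C(O)C(=O)NC(CC(C)C)C1Cc2cccc(O)c2C(=O)O1` gives 100000 ug/mL.

Compound 2 therefore stands at the upper edge of what this assay can report, a position it shares with one other of the three values (the limit of > 100000 ug/mL in this assay, at which 2 of the 3 values shown sit). Compound 4 `CCCCCNC1CC(=O)OC1C(O)C(=O)NC(CC(C)C)C1Cc2cccc(O)c2C(=O)O1` differs from compound 2 by propyl in place of hydrogen on a saturated chain carbon, two bonds along the chain from an amine nitrogen. Among the compounds with values here, two measured steps bear on this change: a number no higher from compound 1 to compound 3 (the limit leaves the size open) and a number no higher from compound 2 to compound 3 (the limit leaves the size open). Both read only as no higher, with their size left open, and the pair of limits makes a step that the two limits leave unreadable from compound 1 to compound 2 unreadable altogether. The known steps thus give no direction beyond the scatter, only a hint that the longest chain measured does not exceed the limit. Compound 4 is expected to stay near the limit, with an estimated step of an at least 1.1-fold lower number from compound 2 to compound 4 (0.04 log units; that floor lies within the scatter). The estimate for compound 4 is 90000 ug/mL, ranging from 30000 ug/mL to 100000 ug/mL.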

Compound 4, solubility: 7300 ug/mL
For compound 4 the middle estimate is 12-fold (1.09 log units) above the measured one; measured number outside the range, below it.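

In this assay, within the data shown here, adding one methyl four bonds along the chain from the amine nitrogen gives a 14-fold lower number from compound 3 to compound 4 (1.14 log units; beyond the scatter), the one new step with a true number at both ends. Among these compounds, the earlier steps among the shorter chains could not be read for size, so this is the first sign that lengthening the chain at this position can matter beyond the scatter. Measured from the two shortest chains, the change is an at least 13-fold lower number from compound 2 to compound 4 (1.13 log units; beyond the scatter) and an at least 13-fold lower number from compound 1 to compound 4 (1.13 log units; beyond the scatter), and both sizes are only floors: the limit of > 100000 ug/mL in this assay, at which 2 of the 4 values shown sit.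

Going by these compounds, whether a longer chain such as hexyl lowers the number further stays open. So does whether a branched chain or a ring such as cyclopentyl on the amine nitrogen would behave like pentyl.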